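Methoxy pattern on the carbonyl-bound phenyl of the enone

The source may hold more compounds than are shown below. What is called first, only, known or untested is meant among the compounds shown, and "the series" means these compounds.

Working notes on the series. The shared core is seen in compound 1 `COc1ccc(-c2cc3ccccc3nc2/C=C/C(=O)c2ccccc2)cc1`, which in a functional assay on NCI-H1299 cells (Homo sapiens) for antiproliferative activity, read by XTT assay, with a stated time of 72 h (on this read-out lower numbers stand for stronger inhibition and higher numbers for weaker inhibition), gives 1410 nM. Compound 2 `COc1ccc(C(=O)/C=C/c2nc3ccccc3cc2-c2ccc(OC)cc2)cc1` gives 6420 nM, and compound 3 `COc1ccc(-c2cc3ccccc3nc2/C=C/C(=O)c2ccc(OC)cc2OC)cc1` gives 3770 nM. On these numbers compound 3 stands second highest of the three: its nearest neighbour is compound 2, with a 1.7-fold lower number from compound 2 to compound 3 (0.23 log units; within the scatter), and its furthest is compound 1, with a 2.7-fold higher number from compound 1 to compound 3 (0.43 log units; beyond the scatter).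

Compound 4 `COc1ccc(-c2cc3ccccc3nc2/C=C/C(=O)c2ccc(OC)c(OC)c2)cc1` differs from compound 3 by 3,4-dimethoxyphenyl in place of 2,4-dimethoxyphenyl on a carbonyl carbon whose other neighbour is a double-bonded chain carbon. Among the measured compounds shown here, no measured step rearranges methoxy groups on the ring attached to that carbonyl carbon; the steps that bear on it add methoxy groups there: a 4.6-fold higher number from compound 1 to compound 2 (0.66 log units; beyond the scatter), a 2.7-fold higher number from compound 1 to compound 3 (0.43 log units; beyond the scatter) and a 1.7-fold lower number from compound 2 to compound 3 (0.23 log units; within the scatter). The first two lay beyond the scatter, the last, the nearest analogy, within it. Compound 4 is therefore expected to stay near compound 3, with a 1.2-fold higher number from compound 3 to compound 4 (0.08 log units; within the scatter) and no step beyond the scatter. The estimate for compound 4 in this assay is 4500 nM, within 2000 nM to 10000 nM.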

Compound 4, half-maximal inhibitory concentration: 1050 nM
Beside the measured number, compound 4's estimate is 4.3-fold (0.63 log units) above it; the measured number lies below the stated range.
By their numbers in this assay, from the lowest: compounds 4 and 1 (each within the scatter of the next); then compounds 3 and 2 (each within the scatter of the next).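

On the phenyl on the carbonyl carbon, the arrangement of the two methoxy groups counts in this assay, not only their number: with the same atoms joined differently, the change from 2,4-dimethoxyphenyl to 3,4-dimethoxyphenyl gives a 3.6-fold lower number from compound 3 to compound 4 (0.56 log units; beyond the scatter). A second methoxy on that ring has no single effect, since one placement gives a 6.1-fold lower number from compound 2 to compound 4 (0.79 log units; beyond the scatter), while the other gives only a 1.7-fold lower number from compound 2 to compound 3 (0.23 log units; within the scatter). The 3,4-dimethoxyphenyl group also stays level with plain phenyl, with a 1.3-fold lower number from compound 1 to compound 4 (0.13 log units; within the scatter), so among the three methoxy-bearing rings shown it alone is not separated from the unsubstituted one, while the other two both give higher numbers beyond the scatter.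

Nothing available here accounts for the difference between the two dimethoxy patterns. Going by these compounds, it remains open whether the 3,4-dimethoxyphenyl level holds with other groups on that ring, such as an amine, a carboxylic acid or a longer alkoxy chain in place of methoxy, and whether the order seen in this assay extends beyond these four compounds.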